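Nitro-to-fluoro swap and tolerated concentration in macrophage cells

The source may hold more compounds than are shown below. What is called first, only, known or untested is meant among the compounds shown, and "the series" means these compounds.

Compound 1 `COC(=O)c1c(NCCNc2ccnc3cc(Cl)ccc23)noc1-c1ccccc1[N+](=O)[O-]` and compound 2 `COC(=O)c1c(NCCCCNc2ccnc3cc(Cl)ccc23)noc1-c1ccccc1[N+](=O)[O-]` carry the same 2-nitrophenyl group and differ in the linker between the two amine nitrogens; the difference between the two cores is not broken down here. In an ADME assay on J774.A1 cells (Mus musculus) for cytotoxicity, read by MTT assay, with a stated time of 48 h (a higher number here means that more compound is tolerated, a lower number that less compound is tolerated), compound 1 gives 73600 nM, and compound 2 gives 77700 nM; these two values lie within the usual scatter of each other, so no order is read from them.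

Compound 3 `COC(=O)c1c(NCCNc2ccnc3cc(Cl)ccc23)noc1-c1ccccc1F` keeps the core of compound 1 but makes the change (fluoro in place of nitro on an aromatic carbon). In this assay compound 3 gives 3420 nM, which is a step of a 22-fold lower number from compound 1 to compound 3 (1.33 log units; beyond the scatter); the change lowers the tolerated concentration by a large margin.

Compound 4 `COC(=O)c1c(NCCCCNc2ccnc3cc(Cl)ccc23)noc1-c1ccccc1F`, not yet measured, applies the same change to compound 2: fluoro in place of nitro on an aromatic carbon. The place of the change reads the same in both pairs, so this is the same change, made on a core that differs only in the linker length. With a single prior example, the expectation rests on that example alone: the step from compound 2 to compound 4 is expected to be about a 20-fold lower number from compound 2 to compound 4 (1.31 log units; beyond the scatter), in line with the earlier step from compound 1 to compound 3 because a 22-fold lower number from compound 1 to compound 3 (1.33 log units; beyond the scatter). On that basis compound 4 is estimated to give about 3800 nM in this assay, with a likely span from 1400 nM to 12000 nM.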

Compound 4, half-maximal cytotoxic concentration: 70900 nM
Beside the measured number, compound 4's estimate is 19-fold (1.27 log units) below it; the measured number lies above the stated range.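

In this assay, putting fluoro in place of nitro on the core of compound 2 gives a 1.1-fold lower number from compound 2 to compound 4 (0.04 log units; within the scatter), so no change can be read from this step, whereas the same swap on the core of compound 1 gave a large one. The swap therefore does not carry over as a fixed step in this series, and its size depends on the core that carries it: the same change on two cores in this assay, a 22-fold lower number (1.33 log units; beyond the scatter) from compound 1 to compound 3 and a 1.1-fold lower number (0.04 log units; within the scatter) from compound 2 to compound 4, 20-fold (1.29 log units) apart, beyond the scatter of two such steps. Going by these compounds alone, this does not show how the linker produces the difference or which of the two steps is the more typical, as only two pairs are available, and it says nothing about why the 2-fluorophenyl group behaves differently on the two cores.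

Still open, on these data alone, is whether the large step belongs to fluoro alone or would also appear with another group in place of nitro, such as chloro, methoxy or an amine. Also open, as far as these compounds go, is how the step behaves with a longer chain as the linker, which would show whether the linker length governs the size of the step or these two cores are simply a pair of separate cases.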